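Swapping nitro for cyano in compound 3

The source may report more compounds than this note shows. Statements on the series, on what has been measured and on what is new or still open speak of the compounds shown alone.

compound 1 `CC(O)(CS(=O)(=O)c1cccc(OC(F)(F)F)c1)C(=O)Nc1ccc(S(F)(F)(F)(F)F)cc1` gives 23700 nM
compound 2 `CC(O)(CS(=O)(=O)c1cccc(S(F)(F)(F)(F)F)c1)C(=O)Nc1cccc(S(F)(F)(F)(F)F)c1` gives 19000 nM
compound 3 `CC1(C)C(=O)N(c2ccc([N+](=O)[O-])c(C(F)(F)F)c2)C(=S)N1c1cccc(S(F)(F)(F)(F)F)c1` gives 100000 nM

These numbers come from a functional assay on VCaP cells (Homo sapiens) for antiproliferative activity, read by propidium iodide staining, with a stated time of 96 h (on this read-out higher numbers stand for weaker inhibition and lower numbers for stronger inhibition), and are all that has been measured so far. Compound 1 and compound 2 sit within the usual scatter of each other. Compound 3 stands apart: at 100000 nM it has the highest number of the three and so the weakest inhibition, beyond the scatter from both of the others.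

The next compound, compound 4 `CC1(C)C(=O)N(c2ccc(C#N)c(C(F)(F)F)c2)C(=S)N1c1cccc(S(F)(F)(F)(F)F)c1`, keeps all of compound 3 except one group. It carries cyano in place of nitro on an aromatic carbon, ortho to a trifluoromethyl group and para to a large group. Counted out, the change is cyano in place of nitro on an aromatic carbon and nothing else differs.

Within the data shown here, no measured pair makes this exchange, so the data offer no direct guide. Compound 3 does leave room for a lower number, since compound 2 on a different core reaches 19000 nM in this assay without any such group. A moderate move towards stronger inhibition is therefore expected, with the estimated step being a 3.3-fold lower number from compound 3 to compound 4 (0.52 log units; beyond the scatter) on this read-out. For compound 4 the estimated value is 30000 nM with an expected range from 6000 nM to 100000 nM around it.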

Compound 4, half-maximal inhibitory concentration: 100000 nM
Compound 4: the middle estimate sits 3.3-fold (0.52 log units) below what was measured, within the range that was stated.
By their numbers in this assay, from the lowest: compounds 2 and 1 (each within the scatter of the next); then compounds 3 and 4 (each within the scatter of the next).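

In this assay the exchange of nitro for cyano on an aromatic carbon, ortho to a trifluoromethyl group and para to a large group, gives no change at the digits printed from compound 3 to compound 4 (within the scatter) and so leaves inhibition where it was. The earlier compounds shown here held no pair that differed only at this position, and this first pair shows that, on the shared core, swapping these two groups does not lower the number. Nothing available explains why the two groups give the same result here.

From the compounds shown here alone, it remains open whether a quite different group on this aromatic carbon, such as an amine, a carboxylic acid or a longer chain, would move the number on the shared core in either direction. Also open, going by these compounds, is whether nitro and cyano would match each other in the same way on a different core, such as that of compound 1.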